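The source may report more compounds than this note shows. Statements on the series, on what has been measured and on what is new or still open speak of the compounds shown alone.

Compound 1, `COc1ccc2c(=O)c(/C=C/C(=O)NCc3ccccc3)coc2c1`, gives 33400 nM in a functional assay on HeLa cells (Homo sapiens) for inhibition, read by MTT assay, with a stated time of 48 h (a higher number here means a weaker inhibitor, a lower number a stronger inhibitor), the lower of the two plain numbers shown. Compound 2, `COc1ccc2c(=O)c(/C=C/C(=O)Nc3cc(C)ccc3C)coc2c1`, gives 58400 nM in this assay, and the step of a 1.7-fold higher number from compound 1 to compound 2 (0.24 log units; within the scatter) stays within the scatter. Compound 3, `COc1ccc2c(=O)c(/C=C/C(=O)NCc3ccccc3F)coc2c1`, reaches only a limit in this assay, > 100000 nM, and the limit of > 100000 nM in this assay, at which 1 of the 3 values shown sits, records that one of the three values sits there. Compound 4, `COc1ccc2c(=O)c(/C=C/C(=O)Nc3ccc(C)cc3)coc2c1`, differs from compound 1 by 4-methylphenyl in place of benzyl on an amide-type nitrogen. The step that bears on this change is a 1.7-fold higher number from compound 1 to compound 2 (0.24 log units; within the scatter), in which 2,5-dimethylphenyl likewise replaced benzyl on the amide-type nitrogen without moving beyond the scatter. Compound 4 is therefore expected to show a 1.3-fold higher number from compound 1 to compound 4 (0.13 log units; within the scatter). The estimate for compound 4 is 45000 nM, with a range from 15000 nM to 140000 nM.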

Compound 4, half-maximal inhibitory concentration: 24100 nM
Estimate against measurement, compound 4: 1.9-fold (0.27 log units) above; the range from low to high includes it.
By their numbers in this assay, from the lowest: compounds 4, 1 and 2 (each within the scatter of the next, the first and the last beyond it). At a limit, above all of these: compound 3.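

In this assay, 4-methylphenyl in place of benzyl on the amide-type nitrogen gives a 1.4-fold lower number from compound 1 to compound 4 (0.14 log units; within the scatter), so these two groups cannot be told apart here. Among the compounds shown here, the aromatic group does separate the compounds, however: a 2.4-fold lower number from compound 2 to compound 4 (0.38 log units; beyond the scatter) is the first step between two plain numbers to pass the scatter, and the other comparison gives an at least 4.1-fold lower number from compound 3 to compound 4 (0.61 log units; beyond the scatter). Compound 3 stands at a limit and not at a number: the limit of > 100000 nM in this assay, at which 1 of the 4 values shown sits.

The compounds shown leave open whether a longer chain, or a 4-aminophenyl or 4-carboxyphenyl group, on the amide-type nitrogen would read differently.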